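Hydroxycyclohexyl on the pyrazole nitrogen: an estimate for compound 3

This account rests on a few compounds, and the source may have more. Where it says the series, first, only, none or still open, it means among the compounds named here.

Measured so far:
compound 1 `CNC(=O)Nc1ccc(-c2nc(N3CC4CCC(C3)O4)c3cnn(C(C)C)c3n2)cc1` gives 5 nM
compound 2 `CNC(=O)Nc1ccc(-c2nc(N3CC4CCC(C3)O4)c3cnn([C@H]4CC[C@H](OC)CC4)c3n2)cc1` gives 2 nM

The two compounds share a core and differ only in the group on the aromatic nitrogen. In a functional assay on LNCaP cells (Homo sapiens) for cytotoxicity (on this read-out lower numbers stand for stronger inhibition and higher numbers for weaker inhibition), compound 1 gives 5 nM, the highest of the two numbers, and compound 2 gives 2 nM. Among the compounds with values here, the single measured step is a 2.5-fold lower number from compound 1 to compound 2 (0.40 log units; beyond the scatter), a modest gain when 4-methoxycyclohexyl replaces isopropyl on the aromatic nitrogen.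

Compound 3 `CNC(=O)Nc1ccc(-c2nc(N3CC4CCC(C3)O4)c3cnn([C@H]4CC[C@H](O)CC4)c3n2)cc1` has not yet been measured. Its change from compound 1 is 4-hydroxycyclohexyl in place of isopropyl on an aromatic nitrogen. Within the data shown here, this step is close to the one from compound 1 to compound 2: the same cyclohexyl ring enters at the same place, carrying a hydroxyl rather than a methoxy group. Among the measured compounds shown here, the only step that bears on it is a 2.5-fold lower number from compound 1 to compound 2 (0.40 log units; beyond the scatter), and a gain of about that size is therefore expected in this assay, small enough that it may fall within the scatter. Compound 3 is estimated at 3 nM, with a range from 1 nM to 8 nM, which corresponds to an expected step of a 1.7-fold lower number from compound 1 to compound 3 (0.22 log units; within the scatter).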

Compound 3, half-maximal inhibitory concentration: 20 nM
Estimate against measurement, compound 3: 6.7-fold (0.82 log units) below; measured number above the stated range.
By their numbers in this assay, from the lowest: compound 2; then compound 1; then compound 3.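

In this assay the cyclohexyl ring alone does not bring the gain seen on the aromatic nitrogen: 4-hydroxycyclohexyl in place of isopropyl gives a 4.0-fold higher number from compound 1 to compound 3 (0.60 log units; beyond the scatter) and so runs against a 2.5-fold lower number from compound 1 to compound 2 (0.40 log units; beyond the scatter) in direction. The substituent on the ring oxygen decides the sign of the change at this position, as hydrogen in place of methyl on an oxygen on a saturated carbon gives a 10-fold higher number from compound 2 to compound 3 (1.00 log units; beyond the scatter) even though the ring and the rest of the molecule stay the same. Nothing available on these compounds accounts for this difference between the hydroxyl and methoxy groups.

The three compounds leave open whether the higher number belongs to the free hydroxyl in particular or whether other replacements for the methoxy group would behave alike, and an ethoxy group, an amine or a carboxylic acid on the cyclohexyl ring would bear on that. They also leave open how the opposite arrangement at the two stereocentres of the ring would read in this assay, since both cyclohexyl compounds shown have the same arrangement.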